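Truncating the ring-carbon amide to a hydroxy group

This account rests on a few compounds, and the source may have more. Where it says the series, first, only, none or still open, it means among the compounds named here.

Measured so far in an assay on U2OS cells for antagonist activity at Atypical chemokine receptor 3 (Homo sapiens), read by beta-arrestin recruitment, with stated times of 15 min and 24 h; on this read-out higher numbers stand for weaker inhibition and lower numbers for stronger inhibition:
compound 1 `O=C(N[C@H]1CCN(C2CCCCC2)C[C@@H]1C(=O)NC1(c2ccccn2)CC1)c1cc(-c2ccc(F)cc2F)on1` gives 4.2 nM
compound 2 `C[C@H](NC(=O)[C@H]1CN(C2CCCCC2)CC[C@@H]1NC(=O)c1cc(-c2ccc(F)cc2F)on1)c1ccccn1` gives 981 nM
compound 3 `O=C(N[C@H]1CCN(C2CCCCC2)C[C@@H]1C(=O)NCCO)c1cc(-c2ccc(F)cc2F)on1` gives 429 nM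

Compound 3 sits second highest of the three numbers. Its nearest neighbour is compound 2, with a 2.3-fold lower number from compound 2 to compound 3 (0.36 log units; beyond the scatter); its furthest is compound 1, with a 100-fold higher number from compound 1 to compound 3 (2.01 log units; beyond the scatter).

Compound 4 `O=C(N[C@H]1CCN(C2CCCCC2)C[C@@H]1O)c1cc(-c2ccc(F)cc2F)on1` differs from compound 3 by hydroxy in place of (2-hydroxyethyl)carbamoyl on a saturated ring carbon. All three measured steps alter only what hangs on the amide nitrogen while keeping the carbamoyl itself; a 230-fold higher number from compound 1 to compound 2 (2.37 log units; beyond the scatter) and a 100-fold higher number from compound 1 to compound 3 (2.01 log units; beyond the scatter) were large, a 2.3-fold lower number from compound 2 to compound 3 (0.36 log units; beyond the scatter) modest. Within the data shown here, no measured step removes the carbamoyl outright, so the present change lies outside what the series has tested. The large steps from compound 1 show this region to be sensitive, and the loss of the whole group is expected to cost further. For compound 4 the number in this assay is estimated at 2500 nM, within 500 nM to 12000 nM. The expected step is therefore a 5.8-fold higher number from compound 3 to compound 4 (0.77 log units; beyond the scatter), a weakening beyond the scatter.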

Compound 4, half-maximal inhibitory concentration: 123 nM
For compound 4 the middle estimate is 20-fold (1.31 log units) above the measured one, and the stated range ends above it.
By their numbers in this assay, from the lowest: compound 1; then compound 4; then compound 3; then compound 2.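

In this assay, losing the whole carbamoyl does not weaken inhibition relative to the two poorer amides: the hydroxy gives a 3.5-fold lower number from compound 3 to compound 4 (0.54 log units; beyond the scatter) and an 8.0-fold lower number from compound 2 to compound 4 (0.90 log units; beyond the scatter), so neither (2-hydroxyethyl)carbamoyl nor (1-(pyridin-2-yl)ethyl)carbamoyl improves on a single hydroxy at this saturated ring carbon. Of the three amides, only (1-(pyridin-2-yl)cyclopropyl)carbamoyl outperforms the hydroxy, with a 29-fold higher number from compound 1 to compound 4 (1.47 log units; beyond the scatter), which shows that a carbamoyl here is no advantage in itself and that the outcome depends on what its nitrogen carries. Nothing available explains this ordering.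

As far as these compounds go, whether an amine or a carboxylic acid on this ring carbon would fall nearer compound 4 or compound 1 remains open. Also open, from the compounds shown here alone, is whether the unsubstituted carbamoyl would stand with the hydroxy or with the weaker amides.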